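Changing one aromatic group on a shared core

This account rests on a few compounds, and the source may have more. Where it says the series, first, only, none or still open, it means among the compounds named here.

Compound 1 `COc1cccc(/C=C2\CCC/C(=C\c3ccc(OC)c(OC)c3)C2=O)c1` gives 11600 nM
Compound 2 `COc1ccc(/C=C2\CCC/C(=C\c3ccc(Cl)c(Cl)c3)C2=O)cc1OC` gives 10100 nM

Among the measured compounds shown here, both numbers come from an ADME assay on NHDF cells (Homo sapiens) for cytotoxicity, read by MTT assay, with a stated time of 72 h (a lower number here means a stronger inhibitor, a higher number a weaker inhibitor), and cannot be told apart, so compound 2 stands level with compound 1, the only other compound measured. For the measured compounds named here, the one measured step is a 1.1-fold lower number from compound 1 to compound 2 (0.06 log units; within the scatter) and it swapped 3-methoxyphenyl for 3,4-dichlorophenyl on a double-bonded chain carbon bound to a double-bonded ring carbon.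

Compound 3 `COc1cc(/C=C2\CCC/C(=C\c3ccc(OC)c(OC)c3)C2=O)ccc1O` has not been measured. It changes that same place again: 4-hydroxy-3-methoxyphenyl in place of 3,4-dichlorophenyl on a double-bonded chain carbon bound to a double-bonded ring carbon and so brings in 4-hydroxy-3-methoxyphenyl, with its hydrogen-bond donor. Going by the values given here, no measured compound carries this group, so a single small step is a thin guide and the range must stay wide. The expected step is a 1.0-fold lower number from compound 2 to compound 3 (0.00 log units; within the scatter) and so no change beyond the scatter is expected. Compound 3 is expected at 10000 nM (estimated range 4000 nM to 25000 nM).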

Compound 3, half-maximal inhibitory concentration: 13700 nM
The estimate for compound 3 lay 1.4-fold (0.14 log units) below the measured number, and the stated range covers the measured number.
By their numbers in this assay, from the lowest: compounds 2, 1 and 3 (each within the scatter of the next).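

In this assay, 4-hydroxy-3-methoxyphenyl brings the first hydrogen-bond donor to this place and gives a 1.4-fold higher number from compound 2 to compound 3 (0.13 log units; within the scatter), so a group with a hydroxy reads level with one carrying two chlorines. Against compound 1, the only difference is hydroxy in place of hydrogen on an aromatic carbon, and that gives a 1.2-fold higher number from compound 1 to compound 3 (0.07 log units; within the scatter), so this single added donor also leaves the compounds impossible to tell apart. No measurement shown here offers an explanation for this result.

Going by these compounds, what stays open is whether any group at this place can move the number beyond the scatter, since all three compounds carry a six-membered aromatic ring of carbon only there. A ring bearing an amine or a carboxylic acid, or a longer chain in place of the ring, would test how far this tolerance extends.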